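Bromo in Place of Methoxy: What to Expect for Compound 4

A few compounds are considered here, and "the series" means these few. Any claim that something is new, unique, unknown or untested is made for them only; others in the source may bear on it.

Measured compounds in a functional assay on A549 cells (Homo sapiens) for inhibition, read by MTT assay, with a stated time of 24 h; on this read-out higher numbers stand for weaker inhibition and lower numbers for stronger inhibition:
compound 1, `CC1(C)[C@H]2CC[C@]1(C)N(Cc1cn(-c3ccc(Cl)cc3)nn1)C(=O)C2`, gives 70 nM
compound 2, `Cc1ccccc1-n1cc(CN2C(=O)C[C@@H]3CC[C@@]2(C)C3(C)C)nn1`, gives 90 nM
compound 3, `COc1ccccc1-n1cc(CN2C(=O)C[C@@H]3CC[C@@]2(C)C3(C)C)nn1`, gives 350 nM

Compound 3 has the highest number of the three in this assay: compound 2 is nearest, compound 1 furthest, both beyond the scatter. Compound 4, `CC1(C)[C@H]2CC[C@]1(C)N(Cc1cn(-c3ccccc3Br)nn1)C(=O)C2`, differs from compound 3 in one place: bromo in place of methoxy on an aromatic carbon.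

Among the measured compounds shown here, no measured step involves a bromo group, so the expectation rests on the steps that lead to compound 3. The step of a 3.9-fold higher number from compound 2 to compound 3 (0.59 log units; beyond the scatter) shows that putting methoxy at this place raised the number beyond the scatter, and a 5.0-fold higher number from compound 1 to compound 3 (0.70 log units; beyond the scatter) points the same way. Removing the methoxy group is therefore expected to undo part of that rise, and the number for compound 4 is expected to move back toward those of compound 1 and compound 2, a step of a 2.9-fold lower number from compound 3 to compound 4 (0.46 log units; beyond the scatter). Compound 4 is thus estimated at 120 nM, within 50 nM to 300 nM.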

Compound 4, half-maximal inhibitory concentration: 130 nM
Compound 4: middle estimate off by 1.1-fold (0.03 log units), on the low side, within the range that was stated.
By their numbers in this assay, from the lowest: compounds 1, 2 and 4 (each within the scatter of the next); then compound 3.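

In this assay the step of a 2.7-fold lower number from compound 3 to compound 4 (0.43 log units; beyond the scatter) shows that the higher number of compound 3 does not come with every group on this aromatic carbon, ortho to a large group: bromo, a second group alongside methyl, does not share it. The steps of a 1.4-fold higher number from compound 2 to compound 4 (0.16 log units; within the scatter) and a 1.9-fold higher number from compound 1 to compound 4 (0.27 log units; within the scatter) both lie within the scatter, so bromo and methyl at this place cannot be told apart, nor can the 2-bromophenyl group and the 4-chlorophenyl group. Among these compounds, methoxy is thus the one group at this place that stands apart.

From the compounds shown here alone, whether an amine, a carboxylic acid or an ethoxy group at this place would go with methoxy or with bromo and methyl remains open. Going by these compounds, what sets methoxy apart from the other two groups also stays open, with no measurement here that bears on it.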